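The source may report more compounds than this note shows. Statements on the series, on what has been measured and on what is new or still open speak of the compounds shown alone.

Measured compounds in a functional assay on SW-620 cells (Homo sapiens) for inhibition; a lower number here means a stronger inhibitor, a higher number a weaker inhibitor:
Compound 1, `CCN1C(=O)NC2(CSC3=C2C(=O)c2ccccc2C3=O)C1=O`, gives 203 nM.
Compound 2, `O=C1C2=C(C(=O)c3ccccc31)C1(CS2)NC(=O)N(CCO)C1=O`, gives 198 nM.
Compound 3, `CN(C)CCCN1C(=O)NC2(CSC3=C2C(=O)c2ccccc2C3=O)C1=O`, gives 58 nM; 60 nM; 65 nM (3 entries).

Compound 2 holds the lower of the two single numbers, with compound 1 nearest; the step of a 1.0-fold lower number from compound 1 to compound 2 (0.01 log units; within the scatter) lies within the scatter, so these two cannot be ordered. Among the compounds with values here, compound 3 carries a longer chain ending in a dimethylamino group; the entries for compound 3, (the several entries of compound 3 in this assay, 58 nM; 60 nM; 65 nM (3 entries)), agree closely and sit lower than the number for compound 2, though no single-change step links the two.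

Compound 4, `CCN(CC)CCN1C(=O)NC2(CSC3=C2C(=O)c2ccccc2C3=O)C1=O`, differs from compound 2 by diethylamino in place of hydroxy on a saturated chain carbon, two bonds along the chain from an amide-type nitrogen in a ring. Within the data shown here, no measured step covers this exchange directly: the one measured step, hydrogen to hydroxy on the same chain carbon, was flat. The nearest guide is the gap between compound 2 and compound 3, where the chain ending in an amine gives the lower number. Compound 4 is therefore expected to give a lower number in this assay than compound 2, a step of about a 2.6-fold lower number from compound 2 to compound 4 (0.42 log units; beyond the scatter). The estimate for compound 4 is 75 nM, expected to fall between 30 nM and 180 nM.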

Compound 4, half-maximal inhibitory concentration: 50 nM
Estimate against measurement, compound 4: 1.5-fold (0.18 log units) above; the measured number falls inside the stated range.
By their numbers in this assay, from the lowest: compound 4; then compounds 2 and 1 (each within the scatter of the next).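

In this assay, the earlier change on this saturated chain carbon, two bonds along the chain from an amide-type nitrogen in a ring, left the number unmoved: a 1.0-fold lower number from compound 1 to compound 2 (0.01 log units; within the scatter) gave no readable difference, so the position could have seemed indifferent to what sits there. Diethylamino on that same carbon shows that it is not, since replacing hydroxy gives a 4.0-fold lower number from compound 2 to compound 4 (0.60 log units; beyond the scatter) and replacing hydrogen gives a 4.1-fold lower number from compound 1 to compound 4 (0.61 log units; beyond the scatter), two steps of nearly the same size that both lie beyond the scatter. Compound 3 also carries a chain ending in an amine, though its chain differs in more than one place, and its repeated readings are tightly grouped, so its low numbers are unlikely to be a single stray reading: the several entries of compound 3 in this assay, 58 nM; 60 nM; 65 nM (3 entries)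

The compounds shown do not separate the nitrogen of diethylamino from the carbons that come with it, a question that a chain ending in a cyclopentyl group, which has a similar number of carbons but no nitrogen, could help to settle. On these data alone, it also remains open how a primary amine, a morpholine ring or a carboxylic acid would behave at this same place.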